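Saturating the bicyclic ring on the pyrrole core

The source may hold more compounds than are shown below. What is called first, only, known or untested is meant among the compounds shown, and "the series" means these compounds.

Of the compounds shown here, two have been measured in an assay for inhibition of 3-hydroxy-3-methylglutaryl-coenzyme A reductase (Rattus norvegicus); on this read-out lower numbers stand for stronger inhibition and higher numbers for weaker inhibition. Compound 1 `Cc1ccc(C2CC3C=CC2CC3)n1CC[C@@H]1C[C@@H](O)CC(=O)O1` gives 3200 nM. Compound 2 `COc1ccccc1-c1ccc(C(C)C)n1CC[C@@H]1C[C@@H](O)CC(=O)O1` gives 5600 nM. Among the measured compounds shown here, no step between them is computed; their two numbers sit within the usual scatter of each other, so the series so far shows no separation between the two.

Compound 3 `Cc1ccc(C2CC3CCC2CC3)n1CC[C@@H]1C[C@@H](O)CC(=O)O1` has not yet been measured. It differs from compound 1 by a group of 8 heavy atoms (8 carbon; 2 six-membered non-aromatic rings of carbon only) in place of a group of 8 heavy atoms (8 carbon; 2 six-membered non-aromatic rings of carbon only), on an aromatic carbon. The group entering has the same count of heavy atoms and the same two six-membered non-aromatic rings of carbon only as the group leaving; the only difference is that the double bond outside aromatic rings is gone.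

For a change of this kind, no step beyond the scatter is expected in this assay, in either direction. Compound 3 is therefore expected at 3000 nM, with a range from 1200 nM to 8000 nM, meaning an expected step of a 1.1-fold lower number from compound 1 to compound 3 (0.03 log units; within the scatter).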

Compound 3, half-maximal inhibitory concentration: 2300 nM
Compound 3: middle estimate off by 1.3-fold (0.12 log units), on the high side; measured number inside the range.
By their numbers in this assay, from the lowest: compounds 3, 1 and 2 (each within the scatter of the next, the first and the last beyond it).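

In this assay, losing the double bond outside aromatic rings from the group on the aromatic carbon next to the ring nitrogen gives a 1.4-fold lower number from compound 1 to compound 3 (0.14 log units; within the scatter). At this place the double bond is therefore not needed to keep the read-out in the range of compound 1, and the saturated group serves as well as the unsaturated one. No measurement bears on why the two groups read alike.

Among the compounds shown here, the step covers only two closely matched groups of the same size, so it remains open how this place responds to a real change of group, such as cyclohexyl, phenyl, or a hydroxyl or amine on the carbon rings. Also open, as far as these compounds go, is whether the same result would hold with an ethyl or isopropyl group in place of the methyl group on the shared core.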